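Swapping the Methoxyphenyl Amide Ring for a Methoxypyridine

The source may hold more compounds than are shown below. What is called first, only, known or untested is meant among the compounds shown, and "the series" means these compounds.

Going by the values given here, compound 2 `COCCn1cc(C(=O)C(=O)Nc2ccc(OC)cc2)c2ccccc21` gives the lowest of the two numbers measured so far: in a functional assay on FaDu cells (Homo sapiens) for cytotoxicity, read by MTT assay, with a stated time of 72 h (on this read-out lower numbers stand for higher toxicity in this test and higher numbers for lower toxicity in this test), compound 2 gives 59 nM. Compound 1 `CCn1cc(C(=O)C(=O)Nc2ccnc(OC)c2)c2ccccc21` differs from compound 2 both in the chain on the shared core and in the ring on the amide nitrogen; in this assay compound 1 gives 4180 nM. Compound 3 `COCCn1cc(C(=O)C(=O)Nc2ccnc(OC)c2)c2ccccc21` keeps the chain of compound 2 and changes only the amide ring: 2-methoxypyridin-4-yl in place of 4-methoxyphenyl on an amide-type nitrogen. Among the compounds with values here, no measured pair isolates this single change, so the outlook rests on the two values shown. The step of a 15-fold higher number from compound 2 to compound 3 (1.18 log units; beyond the scatter) is expected to raise the number beyond the scatter. For compound 3 the estimated value is 900 nM, with a range of 150 nM to 5000 nM.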

Compound 3, concentration lethal to 50% of the cells: 235 nM
Compound 3: middle estimate off by 3.8-fold (0.58 log units), on the high side; the range from low to high includes it.
By their numbers in this assay, from the lowest: compound 2; then compound 3; then compound 1.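

Read alone, the swap to 2-methoxypyridin-4-yl on the amide-type nitrogen gives a 4.0-fold higher number from compound 2 to compound 3 (0.60 log units; beyond the scatter) in this assay and so costs only modestly. Adding methoxy on the chain gives an 18-fold lower number from compound 1 to compound 3 (1.25 log units; beyond the scatter) in this assay and is the larger of the two steps, on the same methoxypyridine amide. Nothing measured here explains either step.

As far as these compounds go, whether the ring swap keeps its size on the chain of compound 1 remains open. So does how an amine or a longer chain would read at the methoxy end of the chain.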